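Changing the Amide Ring Group of Compound 2

The source may report more compounds than this note shows. Statements on the series, on what has been measured and on what is new or still open speak of the compounds shown alone.

Of the compounds shown here, two sharing one core have been measured in an assay on HEK293 cells for positive allosteric modulation of metabotropic glutamate receptor 5 (Homo sapiens), read by FLIPR, with a stated time of 1 h; on this read-out lower numbers stand for an effect already at smaller amounts and higher numbers for an effect only at larger amounts of compound. Compound 1 `CCCCN1CCc2nc(C#Cc3ccccc3)sc2C1` gives 110 nM. Compound 2 `O=C(C1CC12CCC2)N1CCc2nc(C#Cc3ccccc3)sc2C1` replaces the open chain on the ring nitrogen with an amide carrying a small two-ring group, and in this assay compound 2 gives 3.9 nM. Of the two numbers, compound 2 stands lowest; the step of a 28-fold lower number from compound 1 to compound 2 (1.45 log units; beyond the scatter) is the only measured one and it is large.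

Compound 3 `COC1CC(C(=O)N2CCc3nc(C#Cc4ccccc4)sc3C2)C1` keeps the amide but differs from compound 2 by a group of 6 heavy atoms (5 carbon, 1 oxygen; one four-membered non-aromatic ring of carbon only) in place of a group of 6 heavy atoms (6 carbon; one three-membered non-aromatic ring of carbon only, one four-membered non-aromatic ring of carbon only), on a carbonyl carbon. Among the compounds with values here, no measured step swaps one ring group for another on the carbonyl carbon while the amide stays, so the measured step from compound 1 to compound 2 shows only that the amide itself matters greatly; it does not tell how much the choice of ring group on it matters. A step of modest size, if any, is therefore expected. Compound 3 is estimated to give 8 nM, with a likely range from 2.5 nM to 30 nM. The expected step is a 2.1-fold higher number from compound 2 to compound 3 (0.31 log units; beyond the scatter).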

Compound 3, half-maximal effective concentration: 640 nM
The estimate for compound 3 lay 80-fold (1.90 log units) below the measured number; measured number above the stated range.
By their numbers in this assay, from the lowest: compound 2; then compound 1; then compound 3.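

In this assay, the amide alone does not secure a low number: with the ring nitrogen's amide kept, putting 3-methoxycyclobutyl on the carbonyl carbon in place of the two-ring group gives a 160-fold higher number from compound 2 to compound 3 (2.22 log units; beyond the scatter), even though both groups hold the same count of heavy atoms. The new amide also falls behind the open-chain compound, with a 5.8-fold higher number from compound 1 to compound 3 (0.76 log units; beyond the scatter), so the large gain seen earlier belongs to the amide together with its two-ring group and does not carry over to every ring group on that carbonyl carbon. No measured information on hand accounts for this loss.

The change does two things at once, removing the three-membered ring and adding a methoxy oxygen that brings a hydrogen-bond acceptor, and these compounds cannot show which of the two goes with the higher number. A plain cyclobutyl on the carbonyl carbon, with neither the three-membered ring nor the methoxy group, would sit between compound 2 and compound 3 in structure and could help to separate the two changes.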